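A Chlorinated Hydrazone Follows the Phenyl Lead

This account rests on a few compounds, and the source may have more. Where it says the series, first, only, none or still open, it means among the compounds named here.

Among the compounds with values here, compound 1 `CC1=CC[C@@H]([C@@](C)(O)CCCC(C)(C)NC(=S)NN)CC1` gives 49400 nM in a functional assay on HT-29 cells (Homo sapiens) for cytotoxicity, read by sulforhodamine B assay (a lower number here means a stronger inhibitor of growth, a higher number a weaker inhibitor of growth), the highest of the three numbers measured so far. Compound 2 `CC1=CC[C@@H]([C@@](C)(O)CCCC(C)(C)NC(=S)N/N=C\c2ccccc2)CC1` gives 9960 nM in this assay, and compound 3 `CC1=CC[C@@H]([C@@](C)(O)CCCC(C)(C)NC(=S)N/N=C\c2ccc(N(C)C)cc2)CC1` gives 27700 nM in this assay; compound 1 and compound 3 stand within the scatter of each other. Compound 4 `CC1=CC[C@@H]([C@@](C)(O)CCCC(C)(C)NC(=S)N/N=C\c2ccc(Cl)cc2)CC1` differs from compound 1 in this way: a group of 9 heavy atoms (7 carbon, 1 nitrogen, 1 chlorine; one six-membered aromatic ring of carbon only) in place of one nitrogen atom, on an amide-type nitrogen. The nearest measured step is the one in which a phenyl ring was attached at the same nitrogen, a 5.0-fold lower number from compound 1 to compound 2 (0.70 log units; beyond the scatter), a modest drop. The only step made within that aromatic ring, a 2.8-fold higher number from compound 2 to compound 3 (0.44 log units; beyond the scatter), went the other way, but the chlorine has no measured counterpart among these compounds, so its share is unknown. Within the data shown here, the step from compound 1 to compound 4 is therefore expected to resemble the one to compound 2, as a 4.5-fold lower number from compound 1 to compound 4 (0.65 log units; beyond the scatter). Compound 4 is expected to give about 11000 nM in this assay, within a range from 4000 nM to 30000 nM.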

Compound 4, concentration for 50% growth inhibition: 7350 nM
Compound 4: middle estimate off by 1.5-fold (0.18 log units), on the high side; measured number inside the range.
By their numbers in this assay, from the lowest: compounds 4 and 2 (each within the scatter of the next); then compounds 3 and 1 (each within the scatter of the next).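

In this assay, putting chloro in place of hydrogen on the aromatic carbon of the hydrazone left the result within the scatter (a 1.4-fold lower number from compound 2 to compound 4 (0.13 log units; within the scatter)), so no order can be drawn between the chlorinated and the unsubstituted ring. Chloro and dimethylamino at this ring carbon do separate (a 3.8-fold lower number from compound 3 to compound 4 (0.58 log units; beyond the scatter)), and the step from the free amino end survives with chlorine on the ring (a 6.7-fold lower number from compound 1 to compound 4 (0.83 log units; beyond the scatter)). Nothing at hand explains these differences.

From the compounds shown here alone, whether a nitro group or a carboxylic acid on that aromatic carbon would fall with chloro or with dimethylamino stays open. So does whether a cyclohexyl group in place of the aromatic ring would keep the step seen from the free amino end.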